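The source may hold more compounds than are shown below. What is called first, only, known or untested is meant among the compounds shown, and "the series" means these compounds.

For the measured compounds named here, compound 1 `O=C1C(Nc2ccc(I)cc2)=CC(=O)c2c1nc1n2[C@H]2OC[C@@H](O)[C@H]2OC1` holds the only real number in this set; in a functional assay on HeLa cells (Homo sapiens) for inhibition, read by sulforhodamine B assay (a higher number here means a weaker inhibitor, a lower number a stronger inhibitor), compound 1 gives 4010 nM. Compound 2 `O=C1C=C(NC2CCCC2)C(=O)c2c1nc1n2[C@H]2OC[C@@H](O)[C@H]2OC1` reaches only a limit of the assay in this assay, > 16000 nM, which is the level where the limit of > 16000 nM in this assay, at which 1 of the 2 values shown sits, sits. Compound 3 `CCOc1ccc(NC2=CC(=O)c3c(nc4n3[C@H]3OC[C@@H](O)[C@H]3OC4)C2=O)cc1` differs from compound 1 by ethoxy in place of iodo on an aromatic carbon. Going by the values given here, no measured pair shows what this swap does, so the expected step is a 1.4-fold higher number from compound 1 to compound 3 (0.14 log units; within the scatter), a small shift toward weaker inhibition that stays within the usual scatter. Compound 3 is therefore expected to give 5500 nM in this assay, with a range from 2000 nM to 16000 nM.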

Compound 3, half-maximal inhibitory concentration: 14400 nM
Compound 3: the middle estimate sits 2.6-fold (0.42 log units) below what was measured; measured number inside the range.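

For the compounds shown here, the change from 4-iodophenyl to 4-ethoxyphenyl gives the first measured step at this position: in this assay there is a 3.6-fold higher number from compound 1 to compound 3 (0.56 log units; beyond the scatter), so the group carried here matters. Compound 3 still gives a real number, so this step can be read in full. Compound 2 marks where readings stop, with a value that is a limit and not a number: the limit of > 16000 nM in this assay, at which 1 of the 3 values shown sits.

One pair cannot tell whether the weaker inhibition comes from losing iodo or from gaining ethoxy. On these data alone, how a 4-fluorophenyl or a 4-aminophenyl group would behave at this place remains open.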